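Cutting the ester back to a dimethylaminomethyl group

The source may report more compounds than this note shows. Statements on the series, on what has been measured and on what is new or still open speak of the compounds shown alone.

Measured compounds:
Compound 1, `CN(C)c1c(F)c(N)c2c(=O)cc(-c3ccc(N)c(F)c3)oc2c1F`: 39 nM
Compound 2, `CCCCCC(=O)OCc1c(F)c(N)c2c(=O)cc(-c3ccc(N)c(F)c3)oc2c1F`: 160 nM
Compound 3, `CN(C)CC(=O)OCc1c(F)c(N)c2c(=O)cc(-c3ccc(N)c(F)c3)oc2c1F`: 26 nM

These three compounds share one core and differ in a single substituent on it; all were tested in a functional assay on MCF7 cells (Homo sapiens) for cytotoxicity, read by neutral red uptake, with a stated time of 3 days; on this read-out higher numbers stand for weaker inhibition and lower numbers for stronger inhibition. Compound 3 gives the lowest number of the three, yet the step of a 1.5-fold lower number from compound 1 to compound 3 (0.18 log units; within the scatter) lies within the scatter, so compound 1 and compound 3 cannot be told apart, whereas a 6.2-fold lower number from compound 2 to compound 3 (0.79 log units; beyond the scatter) and a 4.1-fold higher number from compound 1 to compound 2 (0.61 log units; beyond the scatter) are clear steps beyond it.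

Compound 4, `CN(C)Cc1c(F)c(N)c2c(=O)cc(-c3ccc(N)c(F)c3)oc2c1F`, has not been measured. Its difference from compound 3 is dimethylamino in place of (((dimethylamino)methyl)carbonyl)oxy on a saturated chain carbon bound to an aromatic carbon. The ester is removed, so the outcome recalls compound 1, which also carries a dimethylamino group on its core and which sits within the scatter of compound 3. The step that bears on this is a 1.5-fold lower number from compound 1 to compound 3 (0.18 log units; within the scatter), small; the larger change seen in a 6.2-fold lower number from compound 2 to compound 3 (0.79 log units; beyond the scatter) does not concern a group kept here. Accordingly no step beyond the scatter is expected, that is a 1.2-fold higher number from compound 3 to compound 4 (0.09 log units; within the scatter). Compound 4 is estimated at 32 nM, with a range from 12 nM to 90 nM.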

Compound 4, half-maximal inhibitory concentration: 72 nM
Estimate against measurement, compound 4: 2.3-fold (0.35 log units) below; measured number inside the range.
By their numbers in this assay, from the lowest: compounds 3, 1 and 4 (each within the scatter of the next, the first and the last beyond it); then compound 2.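

Removing the ester link at this position is not a neutral change: putting dimethylamino in place of (((dimethylamino)methyl)carbonyl)oxy gives a 2.8-fold higher number from compound 3 to compound 4 (0.44 log units; beyond the scatter) and is a step beyond the scatter, which compound 1 alone did not reveal. On the same saturated chain carbon, dimethylamino in place of (pentylcarbonyl)oxy still gives a 2.2-fold lower number from compound 2 to compound 4 (0.35 log units; beyond the scatter) so the long ester remains the poorer of these groups. Moving the amine off the shared core by a single carbon gives a 1.8-fold higher number from compound 1 to compound 4 (0.27 log units; within the scatter) and that step lies within the scatter, so (dimethylamino)methyl and dimethylamino cannot be told apart here.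

From the compounds shown here alone, it remains open whether an amide in place of the ester link, or a morpholine in place of dimethylamino, would match compound 3. Nothing available explains the difference between compound 3 and compound 4.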